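A few compounds are considered here, and "the series" means these few. Any claim that something is new, unique, unknown or untested is made for them only; others in the source may bear on it.

Working notes on a three-membered set sharing one core. Compound 1 `C=CCOc1cc(Br)ccc1C(=O)c1cccnc1` and compound 2 `Cc1ccc(O)c(C(=O)c2cccnc2)c1` are the measured members; compound 3 `C=CCOc1ccccc1C(=O)c1cccnc1` is not yet measured. The read-out is a functional assay on Hep cells (Homo sapiens) for cytotoxicity, read by sulforhodamine B assay, with a stated time of 48 h; on this read-out lower numbers stand for stronger inhibition and higher numbers for weaker inhibition. In this assay compound 1 gives > 100000 nM, which is a limit of the assay and not a number; it sits at the limit of > 100000 nM in this assay, at which 1 of the 2 values shown sits. In this assay compound 2 gives 11000 nM. Going by the values given here, the two differ in more than one place, so no single step between them can be drawn; their values show only that compound 2 reaches a number where compound 1 does not.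

Compound 3 differs from compound 1 by hydrogen in place of bromo on an aromatic carbon. Compound 1 stands at the limit, so the step from compound 1 to compound 3 cannot be computed; the expectation is a step of about an at least 1.2-fold lower number from compound 1 to compound 3 (0.09 log units; that floor lies within the scatter) in this assay, which may be none beyond the scatter. For compound 3 the estimate is 80000 nM, with a range of 20000 nM to 300000 nM.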

Compound 3, half-maximal inhibitory concentration: > 100000 nM
Compound 3 was reported as a limit; the forecaster's own chance of this, stated with the estimate: 60%; middle value at least 1.2-fold (0.09 log units) away from the limit.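

No step can be read from compound 1 to compound 3 in this assay, as both values are limits of the assay and not numbers: the limit of > 100000 nM in this assay, at which 2 of the 3 values shown sit.

The compounds shown leave open whether hydrogen in place of bromo on an aromatic carbon changes the value in this assay at all.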